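The compounds below may be only part of what the source reports. "The series", "measured", "known", "first", "only" and "open" are said of these compounds alone.

Compound 1 `COc1cnc(-c2ccccn2)nc1NCc1ccccc1Cl` is the starting point of this step. In a functional assay on RAW264.7 cells (Mus musculus), with a stated time of 3 days (on this read-out lower numbers stand for stronger inhibition and higher numbers for weaker inhibition), compound 1 gives 520 nM, the highest of the two numbers recorded there. Compound 3 `COc1cnc(-c2ccccn2)nc1NCc1ccc(F)cc1F` gives 110 nM in this assay, and the step of a 4.7-fold lower number from compound 1 to compound 3 (0.67 log units; beyond the scatter) is modest. Compound 2 `COc1cnc(-c2ccccn2)nc1NCCCC(=O)O` reaches only a limit of the assay, > 10000 nM, in this assay. The step of an at least 19-fold higher number from compound 1 to compound 2 (1.28 log units; beyond the scatter) is large, and the step of an at least 90-fold lower number from compound 2 to compound 3 (1.95 log units; beyond the scatter) is large as well; in both, a 2-carboxyethyl chain on the saturated chain carbon bound to a nitrogen on the aromatic ring stands against an aromatic group. Compound 4 `COc1cnc(-c2ccccn2)nc1NCCCCO` has not yet been measured. It differs from compound 1 as follows: 3-hydroxypropyl in place of 2-chlorophenyl on a saturated chain carbon bound to a nitrogen on an aromatic ring. Like compound 2, compound 4 carries a chain with no ring on that carbon, so the step of an at least 19-fold higher number from compound 1 to compound 2 (1.28 log units; beyond the scatter) bears most on it; the step of a 4.7-fold lower number from compound 1 to compound 3 (0.67 log units; beyond the scatter) concerns only an exchange of one aromatic group for another and says little here. Compound 4 is therefore expected to give a much higher number in this assay, an estimated 8000 nM with a range from 2000 nM to 30000 nM, the expected step being a 15-fold higher number from compound 1 to compound 4 (1.19 log units; beyond the scatter). Because one of the three values sits at the limit of > 10000 nM in this assay, at which 1 of the 3 values shown sits, the result for compound 4 may again come back as a limit rather than a number.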

Compound 4, half-maximal inhibitory concentration: 3000 nM
Estimate against measurement, compound 4: 2.7-fold (0.43 log units) above, within the range that was stated.
By their numbers in this assay, from the lowest: compound 3; then compound 1; then compound 4. At a limit, above all of these: compound 2.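

The step of a 5.8-fold higher number from compound 1 to compound 4 (0.76 log units; beyond the scatter) is only modest, so in this assay a chain with no ring on this carbon does not by itself push the number to the assay's limit, as compound 2 alone might have suggested. The aromatic groups still give the lowest numbers of the series, and the 2,4-difluorophenyl group stands furthest from the 3-hydroxypropyl chain, with the large step of a 27-fold higher number from compound 3 to compound 4 (1.44 log units; beyond the scatter). The ring-free chains also differ from each other, as hydroxymethyl in place of carboxy on a saturated chain carbon, three bonds along the chain from a nitrogen on an aromatic ring, gives an at least 3.3-fold lower number from compound 2 to compound 4 (0.52 log units; beyond the scatter), a step that is only a bound, as compound 2 stands at a limit and not at a number: the limit of > 10000 nM in this assay, at which 1 of the 4 values shown sits.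

As far as these compounds go, it remains open whether an amine in place of the hydroxymethyl, or a longer chain ending in hydroxymethyl, would give a number nearer that of compound 4 or the limit of compound 2. From the compounds shown here alone, it is equally open whether a cyclohexyl group in place of 2-chlorophenyl would stay near compound 1 or fall closer to compound 4, which would separate the presence of a ring from its being aromatic.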